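The source may hold more compounds than are shown below. What is called first, only, known or untested is meant among the compounds shown, and "the series" means these compounds.

Measured so far, in a functional assay on HT-29 cells (Homo sapiens) for inhibition, read by sulforhodamine B assay, with a stated time of 48 h; a higher number here means a weaker inhibitor of growth, a lower number a stronger inhibitor of growth:

Compound 1 `O=C1C=CCC(/C=C/c2ccc(C(F)(F)F)cc2)O1`: 36.2 uM
Compound 2 `COc1ccc(/C=C/C2CC=CC(=O)O2)cc1`: 33.7 uM
Compound 3 `O=C1C=CCC(/C=C/c2ccc(C(F)(F)F)cc2)N1`: 139 uM

Compounds 1 and 2 share one core and differ by methoxy in place of trifluoromethyl on an aromatic carbon; the step of a 1.1-fold lower number from compound 1 to compound 2 (0.03 log units; within the scatter). Compound 3 carries a different core, and the difference between the two cores is not broken down here; compound 3 gives a higher number than compound 1 and compound 2, beyond the scatter in both cases.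

Compound 4 `COc1ccc(/C=C/C2CC=CC(=O)N2)cc1` is not yet measured. It differs from compound 3 by methoxy in place of trifluoromethyl on an aromatic carbon, the same change as from compound 1 to compound 2, made at the same place. Because the measured step of a 1.1-fold lower number from compound 1 to compound 2 (0.03 log units; within the scatter) lies within the scatter, the step on the other core is expected to be similar: a 1.1-fold lower number from compound 3 to compound 4 (0.05 log units; within the scatter). Compound 4 is therefore estimated at 125 uM in this assay, most plausibly between 60 uM and 280 uM.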

Compound 4, concentration for growth inhibition (reported as GI): > 1090 uM
Compound 4: no number, only a limit (the forecaster's own chance of this, stated with the estimate: 15%); middle value at least 8.7-fold (0.94 log units) away from the limit.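

In this assay compound 4 gives > 1090 uM, which is a limit of the assay and not a number. The change gives an at least 7.8-fold higher number from compound 3 to compound 4 (0.89 log units; beyond the scatter), so it does not carry over unchanged from the core of compound 1 to the core of compound 3, and the two steps differ: the same change on two cores in this assay, a 1.1-fold lower number (0.03 log units; within the scatter) from compound 1 to compound 2 and an at least 7.8-fold higher number (0.89 log units; beyond the scatter) from compound 3 to compound 4, at least 8.4-fold (0.92 log units) apart, beyond the scatter of two such steps With one pair on each core, this sets no rule for other groups, leaves the full size of the step unknown, and does not show what underlies the difference.

The compounds shown leave open whether other groups at that place, such as a nitrile or an amine, also depend on the core in this way. Also open, from the compounds shown here alone, is how each core behaves with plain hydrogen there.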